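Ring amine variation at the thiocarbonyl carbon

A few compounds are considered here, and "the series" means these few. Any claim that something is new, unique, unknown or untested is made for them only; others in the source may bear on it.

Measured compounds:
compound 1 `N/C(=N\NC(=S)N1CCOCC1)c1ccccn1` gives 69.4% in a functional assay on A-431 cells (Homo sapiens) for cytotoxicity, read by MTT assay, with a stated time of 72 h, tested at 10 uM; on this read-out higher numbers stand for more inhibition of growth at the one concentration tested and lower numbers for less inhibition of growth
compound 2 `Cc1cccc(/C(N)=N/NC(=S)N2CCSCC2)n1` gives 53.2% in this assay
compound 3 `Cc1cccc(/C(N)=N/NC(=S)N2CCOCC2)n1` gives 68.1% in this assay

Compound 3 stands second highest of the three numbers: its gap to compound 1, a number 1.3 percentage points lower from compound 1 to compound 3 (within the scatter), lies within the scatter, whereas its gap to compound 2, a number 14.9 percentage points higher from compound 2 to compound 3 (beyond the scatter), lies beyond it. Compound 4 `Cc1cccc(/C(N)=N/NC(=S)N2CCCC2)n1` differs from compound 3 by pyrrolidin-1-yl in place of morpholin-4-yl on a thiocarbonyl carbon. Among the measured compounds shown here, the only measured step at this position is a number 14.9 percentage points higher from compound 2 to compound 3 (beyond the scatter), a modest one; the step of a number 1.3 percentage points lower from compound 1 to compound 3 (within the scatter) concerns another place. One step cannot fix the direction for a five-membered ring with one hetero atom, so a step of comparable size, in either direction, is plausible in this assay. Compound 4 is therefore expected to give about 60%, between 40% and 78%. This expectation corresponds to a step of a number 8.1 percentage points lower from compound 3 to compound 4 (within the scatter).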

Compound 4, percent growth inhibition at one concentration: 67.6%
Estimate against measurement, compound 4: 7.6 percentage points below; measured number inside the range.
By their numbers in this assay, from the lowest: compound 2; then compounds 4, 3 and 1 (each within the scatter of the next).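

Replacing morpholin-4-yl with pyrrolidin-1-yl on the thiocarbonyl carbon gives no readable change in this assay, the step being a number 0.5 percentage points lower from compound 3 to compound 4 (within the scatter). The oxygen of the morpholin-4-yl ring is therefore not needed to hold this level of growth inhibition in this pair. Thiomorpholin-4-yl now stands apart from two ring amines rather than one, with a number 14.4 percentage points higher from compound 2 to compound 4 (beyond the scatter).

Nothing available explains why compound 2 differs from the others. Open at this position are a piperazin-1-yl ring, a larger azepan-1-yl ring and an open-chain dimethylamino group.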